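Estimating solubility for the pyridazine amide, compound 4

The compounds below may be only part of what the source reports. "The series", "measured", "known", "first", "only" and "open" are said of these compounds alone.

Measured in a physicochemical assay for solubility, measured as kinetic solubility, with a stated time of 1 h, at pH 7.4; a higher number here means a more soluble compound, a lower number a less soluble compound:
Compound 1 `CC(=O)Nc1nc(-c2ccc(Cl)c(C)c2)cs1`: 1000 nM
Compound 2 `NC1=NN(c2ccc(Cl)c(Cl)c2)CC1`: 69000 nM
Compound 3 `N#CCCC(=O)NC1=NN(c2ccc(Cl)c(Cl)c2)CC1`: 39000 nM

Compound 3 shares the top of this short range with compound 2, since the two values lie within the scatter of each other. Compound 1 has a much lower number, but its core differs from that of compound 3.

The next structure is compound 4 `O=C(NC1=NN(c2ccc(Cl)c(Cl)c2)CC1)c1cccnn1`, with pyridazin-3-yl in place of 2-cyanoethyl on a carbonyl carbon. For the measured compounds named here, only one measured step bears on this change, a 1.8-fold lower number from compound 2 to compound 3 (0.25 log units; within the scatter). That step added the group that now leaves and stayed small. Going by the values given here, no measured step shows an aromatic ring entering at this carbonyl, so the evidence is thin, and the range must stay wide. A small drop in this assay is expected, probably not beyond the scatter. The expected step is a 1.8-fold lower number from compound 3 to compound 4 (0.25 log units; within the scatter). Compound 4 is estimated at 22000 nM, with an expected range from 6000 nM to 60000 nM.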

Compound 4, solubility: 67000 nM
Estimate against measurement, compound 4: 3.0-fold (0.48 log units) below, and the stated range ends below it.
By their numbers in this assay, from the lowest: compound 1; then compounds 3, 4 and 2 (each within the scatter of the next).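

In this assay, pyridazin-3-yl in place of 2-cyanoethyl on a carbonyl carbon gives a 1.7-fold higher number from compound 3 to compound 4 (0.24 log units; within the scatter). Among the compounds shown, this is the only one with an aromatic ring at this carbonyl, and it shows that a six-membered aromatic ring with 2 hetero atoms can replace an open chain here while the two values stay within the scatter of each other. No measurement shown here accounts for this result.

As far as these compounds go, whether a phenyl ring, with no ring nitrogen, a piperidine ring or a longer chain would behave the same way at this carbonyl remains open. Also open, from the compounds shown here alone, is what kind of group at this carbonyl, if any, would move the number beyond the scatter on the shared core.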